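The source may hold more compounds than are shown below. What is called first, only, known or untested is meant among the compounds shown, and "the series" means these compounds.

Measured so far:
- compound 1, `CCOC(=O)C1=Cc2ccccc2OC1(OCc1cn(-c2ccc(F)cc2)nn1)C(F)(F)F`, 8900 nM
- compound 2, `CCOC(=O)C1=Cc2ccccc2OC1(OCc1cn(CC(=O)Nc2cccc(Cl)c2)nn1)C(F)(F)F`, 10100 nM

Both compounds share the same core and differ only in the group carried on an aromatic nitrogen of the five-membered ring. In a functional assay on DU-145 cells (Homo sapiens) for inhibition, read by MTT assay, with a stated time of 24 h (a higher number here means a weaker inhibitor, a lower number a stronger inhibitor), compound 2 gives the highest of the two numbers; its nearest neighbour is compound 1, and the step of a 1.1-fold higher number from compound 1 to compound 2 (0.05 log units; within the scatter) lies within the scatter, so the two cannot be told apart on these numbers.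

Compound 3, `CCOC(=O)C1=Cc2ccccc2OC1(OCc1cn(-c2cccc(OC)c2)nn1)C(F)(F)F`, is not yet measured. It differs from compound 2 in one place: 3-methoxyphenyl in place of ((3-chlorophenyl)carbamoyl)methyl on an aromatic nitrogen. Among the compounds with values here, the only measured step that bears on this change is the one from compound 1 to compound 2, a 1.1-fold higher number from compound 1 to compound 2 (0.05 log units; within the scatter), where swapping an aryl group for the carbamoylmethyl chain on the same nitrogen made no difference beyond the scatter. Compound 3 returns an aryl group to that nitrogen, resembling compound 1 more than compound 2. The expected step in this assay is therefore a 1.1-fold lower number from compound 2 to compound 3 (0.05 log units; within the scatter), essentially none beyond the scatter. Compound 3 is estimated at 9000 nM, in the range 4000 nM to 20000 nM.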

Compound 3, half-maximal inhibitory concentration: > 150000 nM
Compound 3 was reported as a limit (the forecaster's own chance of this, stated with the estimate: 10%); middle value at least 16-fold (1.22 log units) from the limit.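

The group on this aromatic nitrogen turns out to matter in this assay: the first two compounds suggested that it could be exchanged with little consequence, yet 3-methoxyphenyl in place of 4-fluorophenyl gives an at least 16-fold higher number from compound 1 to compound 3 (1.22 log units; beyond the scatter). The same 3-methoxyphenyl in place of ((3-chlorophenyl)carbamoyl)methyl gives an at least 14-fold higher number from compound 2 to compound 3 (1.17 log units; beyond the scatter), and compound 1 and compound 3 both carry a six-membered aromatic ring directly on this nitrogen, so having such a ring there does not by itself set the number. The figure for compound 3 is a limit and not a number, which leaves the true size of both steps unknown: the limit of > 150000 nM in this assay, at which 1 of the 3 values shown sits.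

Compound 1 and compound 3 differ both in the group on the aromatic ring and in where it sits, and the compounds shown cannot separate these two changes. As far as these compounds go, a 4-methoxyphenyl or 3-fluorophenyl group on the same nitrogen would bear on that question, while the outcome with an unsubstituted phenyl or an aminophenyl group remains open.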